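Working notes: compound 2 to compound 3 in this series

This account rests on a few compounds, and the source may have more. Where it says the series, first, only, none or still open, it means among the compounds named here.

Measured so far:
compound 1 `COc1ccc(-c2cc(Cc3cccc(OC)c3)c(=O)n(CC(=O)Nc3ccc(F)cc3)n2)cc1`, in a functional assay on HL-60 cells (Homo sapiens), read by calcium flux (on this read-out lower numbers stand for an effect already at smaller amounts and higher numbers for an effect only at larger amounts of compound), compound 1 gives > 50000 nM
compound 2 `Cc1cc(Cc2cccc(F)c2)c(=O)n(CC(=O)Nc2ccc(Br)cc2)n1`, in this assay compound 2 gives > 50000 nM

Both values are limits of the assay, not numbers. In this assay compound 2 sits at the limit, a value that is a limit and nothing more. The same holds for compound 1, whose value is also only a limit. So compound 2 stands where the one other measured value stands, namely at the limit of > 50000 nM in this assay, at which 2 of the 2 values shown sit, and nothing in the measured set separates the two compounds. Among the measured compounds shown here, no step between measured compounds that differ in one place is available.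

Compound 3 `COc1ccc(-c2cc(C)nn(CC(=O)Nc3ccc(Br)cc3)c2=O)cc1` is not yet measured. It differs from compound 2 by 4-methoxyphenyl in place of 3-fluorobenzyl on an aromatic carbon. Compound 1 already carries a 4-methoxyphenyl group and sits at the limit, so the entering group gives no sign of a gain. The step from compound 2 to compound 3 is therefore expected to be none beyond the scatter, most likely with compound 3 again reported only as a limit: a step that the limit leaves unreadable from compound 2 to compound 3. Compound 3 is estimated at 60000 nM, with a range from 15000 nM to 250000 nM.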

Compound 3, half-maximal effective concentration: > 50000 nM
Compound 3 was reported as a limit; the forecaster's own chance of this, stated with the estimate: 80%; the middle value lies beyond the limit too.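

No step can be read from compound 2 to compound 3, as both are reported only as limits in this assay: the limit of > 50000 nM in this assay, at which 3 of the 3 values shown sit.

The compounds shown leave open whether 4-methoxyphenyl and 3-fluorobenzyl differ at all in this assay, and which change to the shared core, if any, would give a value that is not a limit.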